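The source may report more compounds than this note shows. Statements on the series, on what has been measured and on what is new or still open speak of the compounds shown alone.

This study follows an ADME assay on Huh-7 cells (Homo sapiens) for cytotoxicity (a lower number here means that less compound is tolerated, a higher number that more compound is tolerated), across a small set of compounds. Compound 1, `CCCN1CCC(CNCc2cn(-c3ccc([N+](=O)[O-])cc3)nc2-c2ccc(OC(F)(F)F)cc2)CC1`, gives 18000 nM in this assay. Compound 3, `CCCN1CCC(CNCc2cn(-c3ccc([N+](=O)[O-])cc3)nc2-c2ccc(C(F)(F)F)cc2)CC1`, gives 2300 nM. For the measured compounds named here, the only step measured between two compounds, a 7.8-fold lower number from compound 1 to compound 3 (0.89 log units; beyond the scatter), concerns a different group at a different place, so it gives no direct guidance here.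

Compound 2, `CN1CCN(CCNCc2cn(-c3ccc(F)cc3F)nc2Cc2ccccc2)CC1`, stands apart: in this assay compound 2 gives > 20000 nM, which is the limit of > 20000 nM in this assay, at which 1 of the 3 values shown sits, and so is a limit of the assay rather than a number.

Compound 4, `Cc1cccc(-c2nn(-c3ccc(F)cc3F)cc2CNCCN2CCN(C)CC2)c1`, differs from compound 2 by 3-methylphenyl in place of benzyl on an aromatic carbon. Going by the values given here, no measured step bears on this change, and the starting point for compound 2 is itself only a limit, so the expectation rests on that limit alone and a step beyond the scatter cannot be foreseen in either direction.

Compound 4 is therefore expected to give about 20000 nM, with a range from 6000 nM to 40000 nM. The step this estimate means, a number no higher from compound 2 to compound 4 (the limit leaves the size open), is expected to stay within the scatter.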

Compound 4, half-maximal cytotoxic concentration: > 20000 nM
Compound 4: no number, only a limit; the forecaster's own chance of this, stated with the estimate: 50%; the middle value lies on the limit itself.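

Compound 2 and compound 4 both give a limit in this assay rather than a number, so no step can be read between them: the limit of > 20000 nM in this assay, at which 2 of the 4 values shown sit.

Going by these compounds, whether 3-methylphenyl in place of benzyl on an aromatic carbon changes the tolerated concentration at all stays open.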